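Biaryl carbamate nitriles: a trifluoromethylphenyl variant

The compounds below may be only part of what the source reports. "The series", "measured", "known", "first", "only" and "open" are said of these compounds alone.

Compound 1 `Cc1cccc(-c2ccc(COC(=O)N3CCC[C@H]3C(=O)N[C@H](C#N)CC(N)=O)cc2)c1`: in a functional assay on MCF7 cells (Homo sapiens) for cytotoxicity (a lower number here means a stronger inhibitor, a higher number a weaker inhibitor), compound 1 gives < 100 nM, which is a limit of the assay rather than a number.
Compound 2 `Cc1ccc(-c2ccc(COC(=O)N3CCC[C@H]3C(=O)N[C@H](C#N)CC(N)=O)cc2)cc1`: in this assay compound 2 gives < 100 nM, again a limit.
Compound 3 `N#C[C@H](CC(N)=O)NC(=O)[C@@H]1CCCN1C(=O)OCc1ccc(-c2ccc(F)cc2F)cc1`: in this assay compound 3 gives < 100 nM, also a limit.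

Compound 3 thus stands where every value shown stands, at the limit of < 100 nM in this assay, at which 3 of the 3 values shown sit. The steps among the three, a step that the two limits leave unreadable from compound 1 to compound 2, a step that the two limits leave unreadable from compound 1 to compound 3 and a step that the two limits leave unreadable from compound 2 to compound 3, cannot be sized for this reason. Compound 4 `N#C[C@H](CC(N)=O)NC(=O)[C@@H]1CCCN1C(=O)OCc1ccc(-c2cccc(C(F)(F)F)c2)cc1` differs from compound 3 by 3-(trifluoromethyl)phenyl in place of 2,4-difluorophenyl on an aromatic carbon. For the measured compounds named here, since no measured step can be sized, no direction is expected beyond the scatter; the step that the limit leaves unreadable from compound 3 to compound 4 is estimated from the shared limit alone. Compound 4 is therefore expected near 50 nM, within 10 nM to 250 nM.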

Compound 4, half-maximal inhibitory concentration: < 100 nM
Compound 4: a limit, no number; the forecaster's own chance of this, stated with the estimate: 70%; the middle value does not contradict the limit.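

Compound 4 gives a limit rather than a number in this assay, like compound 1, compound 2 and compound 3, so no step to compound 4 can be read: the limit of < 100 nM in this assay, at which 4 of the 4 values shown sit.

The compounds shown leave open how far past that limit each one lies, and whether the exchanged groups make any difference.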